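The compounds below may be only part of what the source reports. "The series", "measured", "known", "first", "only" and "open" are said of these compounds alone.

Working notes on the series. Compound 1 `O=C(Nc1ccc(Oc2ccnc3[nH]ccc23)c(F)c1)c1cn(-c2ccc(F)cc2)c2ccccc2c1=O` is the reference point: in a functional assay on MCF7 cells (Homo sapiens) for inhibition, read by MTT assay, with a stated time of 72 h (a lower number here means a stronger inhibitor, a higher number a weaker inhibitor), compound 1 gives 520 nM. Compound 2 `O=C(Nc1ccc(Oc2ccnc3[nH]ccc23)c(F)c1)c1cn(-c2ccc(Cl)cc2)c2ccccc2c1=O` carries a 4-chlorophenyl in place of the 4-fluorophenyl; for compound 2 this assay reports "not determined" (no result reported), so compound 2 stands on no single number. Compound 3 `O=C(Nc1ccc(Oc2ccnc3[nH]ccc23)c(F)c1)c1cn(-c2ccc(Br)cc2)c2ccccc2c1=O` is the next halogen step: bromo in place of chloro on an aromatic carbon. Among the compounds with values here, no measured step of this kind exists in the set, so a step within the usual scatter, in no firm direction, is expected for compound 3 in this assay. Compound 3 is therefore estimated at 420 nM, with a range of 150 nM to 1200 nM.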

Compound 3, half-maximal inhibitory concentration: 650 nM
For compound 3 the middle estimate is 1.5-fold (0.19 log units) below the measured one; the measured number falls inside the stated range.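

In this assay, bromo in place of fluoro on this aromatic carbon gives a 1.3-fold higher number from compound 1 to compound 3 (0.10 log units; within the scatter) and so leaves the read-out within the scatter, which means this position accepts either halogen without a readable change. The chloro to bromo step cannot be read, as compound 2 has no number. No measured property bears on this result.

The compounds shown leave open how a non-halogen group at this place, such as a methoxy group, an amine or a carboxylic acid, would read. They also leave open whether an unsubstituted phenyl would read the same as the halogenated ones.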